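Ethyl for methyl on the aryl ring of a diketone series

This account rests on a few compounds, and the source may have more. Where it says the series, first, only, none or still open, it means among the compounds named here.

Compound 1 `COC1=C(C)C(=O)/C(=C(O)/C=C/c2ccc(C)cc2)C(=O)C1(C)C` gives, in a functional assay on HUVEC cells (Homo sapiens) (on this read-out lower numbers stand for an effect already at smaller amounts and higher numbers for an effect only at larger amounts of compound), the limit < 4 ug/mL. Compound 2 `CCc1ccc(/C=C/C(O)=C2/C(=O)C(C)=C(OC)C(C)(C)C2=O)cc1` gives in this assay the limit < 4 ug/mL. Compound 3 `CCC1=C(OC)C(CC)(CC)C(=O)C(C(=O)/C=C/c2ccc(C)cc2)=C1O` gives in this assay the limit < 4 ug/mL.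

Compound 1 and compound 2 differ by methyl in place of hydrogen on a saturated chain carbon bound to an aromatic carbon, and the step that the two limits leave unreadable from compound 1 to compound 2 is unreadable since both sit at the limit. The difference between the core of compound 1 and the core of compound 3 is not broken down here. Compound 4 `CCC1=C(OC)C(CC)(CC)C(=O)C(C(=O)/C=C/c2ccc(CC)cc2)=C1O` carries the same change relative to compound 3, (methyl in place of hydrogen on a saturated chain carbon bound to an aromatic carbon). All three values sit at the limit of < 4 ug/mL in this assay, at which 3 of the 3 values shown sit. Because compound 3 rests at the limit of < 4 ug/mL in this assay, at which 3 of the 3 values shown sit, the step is estimated as a step that the limit leaves unreadable from compound 3 to compound 4. Compound 4 is therefore expected to give 2 ug/mL, with a range estimated from 0.5 ug/mL to 4 ug/mL, most likely again reported only as a limit.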

Compound 4, concentration for half-maximal effect: < 4 ug/mL
Compound 4: no number, only a limit (the forecaster's own chance of this, stated with the estimate: 80%); the middle value does not contradict the limit.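

No step can be read between compound 3 and compound 4, because both values are limits: the limit of < 4 ug/mL in this assay, at which 4 of the 4 values shown sit.

The compounds shown leave open whether 4-methylphenyl and 4-ethylphenyl differ at all in this assay.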